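A quinolin-8-yl group in place on compound 1

The source may hold more compounds than are shown below. What is called first, only, known or untested is meant among the compounds shown, and "the series" means these compounds.

In a functional assay on K562 cells (Homo sapiens) for inhibition, read by trypan blue exclusion, with a stated time of 72 h (on this read-out lower numbers stand for stronger inhibition and higher numbers for weaker inhibition), compound 1 (`Cc1ccc(S(=O)(=O)c2cc3cnc(Nc4cnc5c(c4)CC(=O)N5)nc3n(C)c2=O)cc1`) gives 15000 nM, the highest of the three numbers measured. Compound 2 (`Cn1c(=O)c(S(=O)(=O)c2ccc(F)cc2)cc2cnc(Nc3ccc4[nH]ccc4c3)nc21`) gives 200 nM and compound 3 (`Cn1c(=O)c(S(=O)(=O)c2ccc(F)cc2[N+](=O)[O-])cc2cnc(Nc3ccc4[nH]ccc4c3)nc21`) gives 900 nM. Compound 4 (`Cc1ccc(S(=O)(=O)c2cc3cnc(Nc4cccc5cccnc45)nc3n(C)c2=O)cc1`) departs from compound 1 by one change, (a group of 10 heavy atoms (9 carbon, 1 nitrogen; one six-membered aromatic ring of carbon only, one six-membered aromatic ring with 1 hetero atom) in place of a group of 10 heavy atoms (7 carbon, 2 nitrogen, 1 oxygen; one five-membered non-aromatic ring with 1 hetero atom, one six-membered aromatic ring with 1 hetero atom), on a nitrogen on an aromatic ring), and the entering group is quinolin-8-yl.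

Going by the values given here, the only measured step, a 4.5-fold higher number from compound 2 to compound 3 (0.65 log units; beyond the scatter), is modest and comes with nitro in place of hydrogen on an aromatic carbon, so it does not touch the group that changes here. It shows only that a single substitution elsewhere moved this assay by a moderate amount. Indirect support comes from compound 2 at 200 nM and compound 3 at 900 nM, which also lack the leaving group but differ from compound 1 in the sulfonyl aryl as well. A clear move towards a lower number is therefore expected, though with wide uncertainty. The estimated change is a 5.0-fold lower number from compound 1 to compound 4 (0.70 log units; beyond the scatter). Compound 4 is expected at 3000 nM, with an estimated range of 600 nM to 15000 nM.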

Compound 4, half-maximal inhibitory concentration: 10000 nM
Compound 4: the middle estimate sits 3.3-fold (0.52 log units) below what was measured; low and high end bracket the measured number.
By their numbers in this assay, from the lowest: compound 2; then compound 3; then compounds 4 and 1 (each within the scatter of the next).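

In this assay the replacement of the leaving group by quinolin-8-yl gives a 1.5-fold lower number from compound 1 to compound 4 (0.18 log units; within the scatter) and this lies within the scatter, so the two groups cannot be told apart at this position on the aromatic-ring nitrogen. Going by these compounds alone, this is the first measured step at this place, and it holds even though the groups differ in their rings and in their counts, with 1 hydrogen-bond donor in the leaving group and 0 hydrogen-bond donors in quinolin-8-yl. Nothing measured on these compounds accounts for this absence of a clear step.

Compound 2 and compound 3 differ from compound 4 in more than one place, so what lies behind their separate numbers stays open. Also open, on these data alone, is whether an amine or a carboxylic acid on the quinolin-8-yl group would shift the number in this assay beyond the scatter.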